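This account rests on a few compounds, and the source may have more. Where it says the series, first, only, none or still open, it means among the compounds named here.

Compound 1 `O=C(NCCCCN1CCCCC1)Nc1ccc(-c2ccccc2)cc1`: 7900 nM in a functional assay on HEK293 cells for agonist activity at 5-hydroxytryptamine receptor 3A (Homo sapiens), read by FLIPR; on this read-out lower numbers stand for stronger inhibition and higher numbers for weaker inhibition.
Compound 2 `O=C(NCCCCN1CCCCC1)Nc1ccc(-c2ccccn2)nc1`: > 30000 nM, a limit of the assay.
Compound 3 `O=C(NCCCCN1CCCCC1)Nc1ccc(-c2ccccn2)cc1`: > 30000 nM, also a limit of the assay.

Compound 1 gives a number in this assay, while compound 2 and compound 3 each stop at a limit. The difference between the cores of compound 2 and compound 3 is not broken down here. From compound 3 to compound 1 the change is phenyl in place of pyridin-2-yl on an aromatic carbon, and it gave an at least 3.7-fold lower number from compound 3 to compound 1 (0.57 log units; beyond the scatter). Compound 4 `O=C(NCCCCN1CCCCC1)Nc1ccc(-c2ccccc2)nc1` arises from compound 2 by the same kind of change, (phenyl in place of pyridin-2-yl on an aromatic carbon), the place now lying next to the ring nitrogen. From the compounds shown here alone, because the limit of > 30000 nM in this assay, at which 2 of the 3 values shown sit, caps the starting point of compound 2, the true size of that step is unknown. Compound 4 is expected to move by about an at least 1.5-fold lower number from compound 2 to compound 4 (0.17 log units; that floor lies within the scatter), resting on an at least 3.7-fold lower number from compound 3 to compound 1 (0.57 log units; beyond the scatter). The estimate for compound 4 is 20000 nM, expected between 5000 nM and 60000 nM.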

Compound 4, half-maximal inhibitory concentration in the 5-hydroxytryptamine receptor 3A assay: > 30000 nM
Compound 4 ended at the assay's limit; the forecaster's own chance of this, stated with the estimate: 45%; middle value at least 1.5-fold (0.17 log units) from the limit.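

In the 5-hydroxytryptamine receptor 3A assay compound 2 gives > 30000 nM as a limit of the assay. In the 5-hydroxytryptamine receptor 3A assay compound 4 gives > 30000 nM as a limit of the assay too. No step from compound 2 to compound 4 can be read in the 5-hydroxytryptamine receptor 3A assay, because both compounds stop at the same limit: the limit of > 30000 nM in the 5-hydroxytryptamine receptor 3A assay, at which 3 of the 4 values shown sit.

From the compounds shown here alone, whether phenyl in place of pyridin-2-yl changes this read-out at all on the core of compound 2 stays open.

In a physicochemical assay for solubility, at pH 7.4 (a lower number here means a less soluble compound, a higher number a more soluble compound), compound 2 gives 171000 nM and compound 4 gives 193000 nM as measured values. In the physicochemical assay the measured step is a 1.1-fold higher number from compound 2 to compound 4 (0.05 log units; within the scatter) and no more.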